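The compounds below may be only part of what the source reports. "The series", "measured", "known", "first", "only" and "open" are said of these compounds alone.

Measured compounds:
compound 1 `Oc1ccccc1-c1cc(-c2cccs2)cc(-c2ccccc2O)n1`: 77.2%
compound 2 `Oc1cccc(-c2cc(-c3cccs3)cc(-c3ccccc3O)n2)c1`: 83.2%

In an assay on isolated protein for inhibition of DNA topoisomerase 1 (Homo sapiens), with a stated time of 30 min, tested at 100 uM (a lower number here means a weaker effect, a higher number a stronger effect of the compound at the concentration tested), compound 2 gives 83.2% and stands at the top of the two numbers shown, with compound 1 the nearest; the step of a number 6 percentage points higher from compound 1 to compound 2 (within the scatter) is within the scatter, so the two are not distinguished. Compound 3 `Oc1ccc(-c2cc(-c3cccs3)cc(-c3ccccc3O)n2)cc1` differs from compound 2 by 4-hydroxyphenyl in place of 3-hydroxyphenyl on an aromatic carbon. Among the compounds with values here, the only step that bears on this change is a number 6 percentage points higher from compound 1 to compound 2 (within the scatter), and it was within the scatter. For compound 3 this means an expected step of a number 3.2 percentage points lower from compound 2 to compound 3 (within the scatter), none beyond the scatter. Compound 3 is therefore estimated at 80%, within a range from 65% to 92%.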

Compound 3, a percentage reported as inhibition, at one concentration (the size of the read-out at that concentration, not a potency): 72.2%
Estimate against measurement, compound 3: 7.8 percentage points above; the measured number falls inside the stated range.
By their numbers in this assay, from the lowest: compounds 3, 1 and 2 (each within the scatter of the next, the first and the last beyond it).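

In this assay the position next to the ring nitrogen now shows a step beyond the scatter, as 4-hydroxyphenyl in place of 3-hydroxyphenyl gives a number 11 percentage points lower from compound 2 to compound 3 (beyond the scatter) on the shared core. By contrast, 4-hydroxyphenyl in place of 2-hydroxyphenyl gives a number 5 percentage points lower from compound 1 to compound 3 (within the scatter) and does not separate the two, so only the 3-hydroxyphenyl and 4-hydroxyphenyl pair is distinguished. Nothing available accounts for this difference. Open, on these data alone, is whether a group other than hydroxyphenyl at this position, such as an aminophenyl or a methoxyphenyl, would hold or lose the effect.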